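Swapping a Methoxyphenyl Ring for a Thiophene Ring

This account rests on a few compounds, and the source may have more. Where it says the series, first, only, none or still open, it means among the compounds named here.

Of the compounds shown here, three sharing one core have been measured in a functional assay on Jurkat cells for inhibition of nuclear factor NF-kappa-B complex (Homo sapiens); on this read-out lower numbers stand for stronger inhibition and higher numbers for weaker inhibition. Compound 1 `CCOC(=O)c1cnc(-c2ccccc2)nc1NN1C(=O)C=C(C)C1=O` gives 100 nM, compound 2 `CCOC(=O)c1cnc(-n2nc(C)cc2C)nc1NN1C(=O)C=C(C)C1=O` gives 10000 nM, and compound 3 `CCOC(=O)c1cnc(-c2ccc(OC)cc2)nc1NN1C(=O)C=C(C)C1=O` gives 900 nM, the second highest of the three numbers, sitting between the other two. Compound 4 `CCOC(=O)c1cnc(-c2ccsc2)nc1NN1C(=O)C=C(C)C1=O` carries thiophen-3-yl in place of 4-methoxyphenyl on an aromatic carbon. Among the compounds with values here, two measured steps bear on this change: adding a methoxy gave a 9.0-fold higher number from compound 1 to compound 3 (0.95 log units; beyond the scatter), while replacing the 3,5-dimethyl-1H-pyrazol-1-yl ring gave an 11-fold lower number from compound 2 to compound 3 (1.05 log units; beyond the scatter). Compound 4 drops the methoxy yet keeps a plain aromatic ring in its place, as compound 1 does, so the expected change is a 3.6-fold lower number from compound 3 to compound 4 (0.56 log units; beyond the scatter). Compound 1 with 100 nM is the nearest guide. Compound 4 is therefore expected to give about 250 nM, within 60 nM to 1500 nM.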

Compound 4, half-maximal inhibitory concentration: 100 nM
Estimate against measurement, compound 4: 2.5-fold (0.40 log units) above, within the range that was stated.
By their numbers in this assay, from the lowest: compounds 1 and 4 (each within the scatter of the next); then compound 3; then compound 2.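

In this assay, thiophen-3-yl in place of phenyl gives no change at the digits printed from compound 1 to compound 4 (within the scatter) and so shows that this position accepts a five-membered aromatic ring as well as a six-membered one of carbon only. Thiophen-3-yl in place of 4-methoxyphenyl gives a 9.0-fold lower number from compound 3 to compound 4 (0.95 log units; beyond the scatter) and in place of 3,5-dimethyl-1H-pyrazol-1-yl gives a 100-fold lower number from compound 2 to compound 4 (2.00 log units; beyond the scatter) and so ring size alone does not set the number, since the weakest group here is also a five-membered ring.

On these data alone, whether a phenyl or thiophen-3-yl ring carrying an amine or a carboxylic acid would hold this level stays open. Nothing measured here explains why these groups differ.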